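Swapping an Ethynyl Group for an Oxirane Ring

The compounds below may be only part of what the source reports. "The series", "measured", "known", "first", "only" and "open" are said of these compounds alone.

Two compounds have been followed in an ADME assay for pharmacokinetics, read by LC-MS, in phosphate buffer, with a stated time of 72 h, at pH 7.4, tested at 250 uM; a higher number here means that the compound lasts longer, a lower number that the compound disappears faster. Compound 1 `O=C1C=CC(=O)N1c1cc(C(F)(F)F)cc(C(F)(F)F)c1` gives < 0.017 h, which is a limit of the measurement rather than a number. Among the measured compounds shown here, compound 2 `C#Cc1cc(C(F)(F)F)cc(C(F)(F)F)c1` gives 5.9 h in this assay, and this is the only plain number so far. For the measured compounds named here, the single measured step, an at least 340-fold higher number from compound 1 to compound 2 (2.54 log units; beyond the scatter), shows that exchanging the group on that aromatic carbon can shift the half-life a long way, though its true size is bounded only by the limit of < 0.017 h in this assay, at which 1 of the 2 values shown sits. Compound 3 `FC(F)(F)c1cc(C2CO2)cc(C(F)(F)F)c1` differs from compound 2 by oxiran-2-yl in place of ethynyl on an aromatic carbon. Going by the values given here, no measured step touches an oxirane ring, so the step already seen sets only how wide such swaps can range. A smaller step than that one, in either direction, is expected here. Compound 3 is therefore expected to give 30 h, between 8 h and 100 h, amounting to a 5.1-fold higher number from compound 2 to compound 3 (0.71 log units; beyond the scatter).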

Compound 3, half-life: > 50 h
Compound 3: a limit, no number; the forecaster's own chance of this, stated with the estimate: 25%; middle value at least 1.6-fold (0.22 log units) from the limit.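

Compound 3 stands at a limit of this assay, which is not a number: the limit of > 50 h in this assay, at which 1 of the 3 values shown sits.

Even so, replacing ethynyl with oxiran-2-yl on this aromatic carbon gives an at least 8.4-fold higher number from compound 2 to compound 3 (0.92 log units; beyond the scatter), so this three-membered ring with its oxygen does not shorten the half-life compared with ethynyl, something the earlier compounds could not show. From the compounds shown here alone, the range seen at this position now widens to an at least 2900-fold higher number from compound 1 to compound 3 (3.46 log units; beyond the scatter), and since both ends of that range are limits, its true size remains unknown.

The compounds shown leave open how long compound 3 actually lasts. They also do not tell how an amine, a carboxylic acid or a longer chain on this same aromatic carbon would behave in this assay.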